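Cytotoxicity notes on a 2-aryl quinazoline amine series

The source may hold more compounds than are shown below. What is called first, only, known or untested is meant among the compounds shown, and "the series" means these compounds.

Compound 3 `CN1CCN(CCCNc2nc(-c3ccc(F)cc3)nc3ccccc23)CC1` gives the highest of the two numbers in a toxicity assay on cells (Macrophage, Homo sapiens) for inhibition, read by MTT assay; a lower number here means a stronger inhibitor, a higher number a weaker inhibitor: compound 3 gives 40000 nM. Compound 2 `NCCCCNc1nc(-c2ccc(Cl)cc2)nc2ccccc12` gives 13000 nM in this assay, a lower number that lies beyond the scatter. Compound 1 `CN1CCN(CCCNc2nc(-c3ccc(Cl)cc3)nc3ccccc23)CC1` gives "nd" (no result reported) in this assay. The next compound, compound 4 `NCCNc1nc(-c2ccc(F)cc2)nc2ccccc12`, differs from compound 3 by the change (amino in place of (4-methylpiperazin-1-yl)methyl on a saturated chain carbon, two bonds along the chain from a nitrogen on an aromatic ring). Compound 2 already carries a plain primary amine at the chain end and shows the lower number of the two. The step of a 1.6-fold lower number from compound 3 to compound 4 (0.20 log units; within the scatter) is therefore expected to be small, toward a lower number, and possibly not beyond the scatter. Compound 4 is estimated at 25000 nM in this assay, with a range of 8000 nM to 80000 nM.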

Compound 4, half-maximal inhibitory concentration: 64000 nM
The estimate for compound 4 lay 2.6-fold (0.41 log units) below the measured number, within the range that was stated.
By their numbers in this assay, from the lowest: compound 2; then compounds 3 and 4 (each within the scatter of the next).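

Exchanging (4-methylpiperazin-1-yl)methyl for amino on a saturated chain carbon, two bonds along the chain from a nitrogen on an aromatic ring, gives a 1.6-fold higher number from compound 3 to compound 4 (0.20 log units; within the scatter) in this assay. This first single-place comparison in the series shows that removing the whole ring-bearing group leaves no difference that can be separated from the scatter at this position. No measurement at hand bears on this result.

Compound 2 and compound 4 differ in more than one place, so chain length and the halogen remain unseparated. Also open, on these data alone, is how a carboxylic acid or a dimethylamino group at the chain end would read.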